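From heptylcarbonyl to methyl on the shared core

This account rests on a few compounds, and the source may have more. Where it says the series, first, only, none or still open, it means among the compounds named here.

compound 1 (`C=C[C@@](C)(/C=C/c1ccc(OC(C)=O)cc1)CCC=C(C)C`) gives 63%
compound 2 (`C=C[C@@](C)(/C=C/c1ccc(OC(=O)CCCCCCC)cc1)CCC=C(C)C`) gives 53%

Compound 2 stands at 53% in a functional assay on HeLa cells (Homo sapiens) for inhibition, with a stated time of 48 h, tested at 50 uM (a lower number here means less inhibition of growth, a higher number more inhibition of growth at the concentration tested), and lies within the scatter of compound 1 (at 63%), so neither ranks above the other. The change to compound 3 (`C=C[C@@](C)(/C=C/c1ccc(OC)cc1)CCC=C(C)C`) is methyl in place of heptylcarbonyl on an oxygen on an aromatic ring and amounts to methyl in place of heptylcarbonyl on an oxygen on an aromatic ring. For the measured compounds named here, the only measured step that bears on it is a number 10 percentage points lower from compound 1 to compound 2 (within the scatter) and that step alters just the chain on the carbonyl carbon. Going by the values given here, no measured pair shows what follows when the carbonyl itself is gone, so the evidence is thin. With a single step inside the scatter as the guide, no step beyond the scatter is expected in this assay and no firm direction can be given. The step expected is a number 5 percentage points higher from compound 2 to compound 3 (within the scatter) and the wide range reflects the untested change. Compound 3 is estimated at 58% (range 40% to 75%).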

Compound 3, percent growth inhibition at one concentration: 43%
Compound 3: middle estimate off by 15 percentage points, on the high side, within the range that was stated.
By their numbers in this assay, from the lowest: compounds 3, 2 and 1 (each within the scatter of the next, the first and the last beyond it).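

In this assay, for the compounds shown here, methyl in place of acetyl on an oxygen on an aromatic ring gives a number 20 percentage points lower from compound 1 to compound 3 (beyond the scatter), the first step beyond the scatter, so the group on this oxygen can shift growth inhibition, where the earlier pair, which changed only the chain on the carbonyl carbon, showed no such shift. Methyl in place of heptylcarbonyl at the same place gives a number 10 percentage points lower from compound 2 to compound 3 (within the scatter), so loss of the carbonyl-bearing group does not separate the compounds in every case, and compound 2 goes against any rule that both carbonyl-bearing compounds clearly exceed the methyl compound. No measurement on hand explains the step beyond the scatter.

The shown compounds leave open whether the carbonyl or the chain length matters more, since heptyl directly on this oxygen would separate the two, and a free hydroxyl there would show how the core behaves without either group. From the compounds shown here alone, whether the order of compound 1 and compound 3 holds at other concentrations or in other cell lines also remains open.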